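The source may hold more compounds than are shown below. What is called first, only, known or untested is meant among the compounds shown, and "the series" means these compounds.

In an ADME assay on THP-1 cells (Homo sapiens) for cytotoxicity (on this read-out higher numbers stand for lower toxicity in this test and lower numbers for higher toxicity in this test), compound 3 `O=C(Nc1ccc(OC(F)(F)F)cc1)c1c(NC(=O)C(F)(F)F)sc2c1CCCCC2` gives 11900 nM, within the scatter of compound 1 `O=C(Nc1ccc(C(F)(F)F)cc1)c1c(NC(=O)C(F)(F)F)sc2c1CCCCC2` at 17200 nM. Compound 2 `COc1ccc(CNC(=O)c2c(NC(=O)C(F)(F)F)sc3c2CCCCC3)cc1` reaches only a limit of the assay, > 50000 nM. Compound 4 `Cc1ccc(NC(=O)c2c(NC(=O)C(F)(F)F)sc3c2CCCCC3)cc1` has methyl in place of trifluoromethoxy on an aromatic carbon, para to a large group: methyl in place of trifluoromethoxy on an aromatic carbon. The closest measured change is at that same aromatic carbon, a 1.4-fold lower number from compound 1 to compound 3 (0.16 log units; within the scatter), and it stays within the scatter. The step of an at least 2.9-fold higher number from compound 1 to compound 2 (0.46 log units; beyond the scatter) is beyond the scatter, but it changes the group on the amide-type nitrogen, so it bears only weakly here. The expected change is therefore no more than the scatter, a 1.5-fold higher number from compound 3 to compound 4 (0.18 log units; within the scatter). For compound 4, the estimated value is 18000 nM, with an expected range of 8000 nM to 45000 nM.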

Compound 4, half-maximal cytotoxic concentration: > 50000 nM
Compound 4 ended at the assay's limit; the forecaster's own chance of this, stated with the estimate: 15%; at least 2.7-fold (0.44 log units) between middle value and limit.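

In this assay, methyl in place of trifluoromethoxy gives an at least 4.2-fold higher number from compound 3 to compound 4 (0.62 log units; beyond the scatter), and methyl in place of trifluoromethyl gives an at least 2.9-fold higher number from compound 1 to compound 4 (0.46 log units; beyond the scatter). This aromatic carbon therefore responds to substitution: trifluoromethyl and trifluoromethoxy stay within the scatter of each other, while methyl moves the number beyond it, towards lower toxicity in this test. The step between compound 2 and compound 4 cannot be read, and the other two steps give only minimum sizes: the limit of > 50000 nM in this assay, at which 2 of the 4 values shown sit.

From the compounds shown here alone, the true size of the methyl effect remains open. Going by these compounds, it is also open whether chlorine, a hydroxyl or an amine at this carbon would track methyl or the two fluorinated groups.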